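The compounds below may be only part of what the source reports. "The series", "measured", "known", "first", "only" and "open" are said of these compounds alone.

Compound 1 `COc1cc(-c2nn(-c3cccc(NC(=O)Nc4cc(C(F)(F)F)cc(C(F)(F)F)c4)c3)cc2-c2ccncc2)ccc1Cl`: 886 nM in a functional assay on MDA-MB-435 cells (Homo sapiens) for inhibition, read by sulforhodamine B assay, with a stated time of 48 h; on this read-out lower numbers stand for stronger inhibition of growth and higher numbers for weaker inhibition of growth
Compound 2 `COc1cc(-c2nn(-c3cccc(NC(=O)c4cccc(C(F)(F)F)c4)c3)cc2-c2ccncc2)ccc1Cl`: 705 nM in this assay

Of the two numbers in this assay, compound 2 gives the lower one, though the gap to compound 1 is within the scatter. Compound 3 `COc1cc(-c2nn(-c3cccc(NC(=O)Nc4cccc(C(F)(F)F)c4)c3)cc2-c2ccncc2)ccc1Cl` differs from compound 2 in one place: (3-(trifluoromethyl)phenyl)amino in place of 3-(trifluoromethyl)phenyl on a carbonyl carbon. For the measured compounds named here, no measured pair shows this change on its own, so no measured step can be read off. The expectation for compound 3 in this assay is a step of a 1.3-fold higher number from compound 2 to compound 3 (0.11 log units; within the scatter), no larger than the scatter. Compound 3 is estimated at 900 nM, between 350 nM and 2500 nM.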

Compound 3, concentration for 50% growth inhibition: 866 nM
Compound 3: middle estimate off by 1.0-fold (0.02 log units), on the high side; measured number inside the range.
By their numbers in this assay, from the lowest: compounds 2, 3 and 1 (each within the scatter of the next).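

In this assay, (3-(trifluoromethyl)phenyl)amino in place of 3-(trifluoromethyl)phenyl on a carbonyl carbon gives a 1.2-fold higher number from compound 2 to compound 3 (0.09 log units; within the scatter) with one more hydrogen-bond donor. Hydrogen in place of trifluoromethyl on an aromatic carbon gives a 1.0-fold lower number from compound 1 to compound 3 (0.01 log units; within the scatter) in the same measurement. Both steps lie within the scatter, so neither change separates these compounds on this read-out.

As far as these compounds go, whether a different group on that aromatic carbon, such as an amine or a carboxylic acid, would move the number beyond the scatter remains open. Nothing measured here bears on the reason for these results.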